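A few compounds are considered here, and "the series" means these few. Any claim that something is new, unique, unknown or untested is made for them only; others in the source may bear on it.

Compounds measured so far:
compound 1, `COc1cc(/C=C/c2ccc(S(N)(=O)=O)cc2)cc(OC)c1`, 18700 nM
compound 2, `COc1cccc(/C=C/c2ccc(S(N)(=O)=O)cc2)c1`, 17400 nM
compound 3, `NS(=O)(=O)c1ccc(/C=C/c2ccc(F)cc2)cc1`, 27000 nM

In a functional assay on MDA-MB-435 cells (Homo sapiens) for inhibition (a higher number here means a weaker inhibitor of growth, a lower number a stronger inhibitor of growth), compound 3 sits alongside compound 1 and compound 2, the three numbers falling within the scatter of one another, so no ordering among them is claimed. The next compound in the series is compound 4, `CN(C)c1ccc(/C=C/c2ccc(S(N)(=O)=O)cc2)cc1`. Relative to compound 3 the change is dimethylamino in place of fluoro on an aromatic carbon. Among the compounds with values here, the only measured step of one change, a 1.1-fold lower number from compound 1 to compound 2 (0.03 log units; within the scatter), concerns a methoxy at a different place and stayed within the scatter; no measured step covers fluoro against dimethylamino. With nothing to point either way, compound 4 is expected to stay near compound 3, the step of a 1.4-fold lower number from compound 3 to compound 4 (0.13 log units; within the scatter) estimated to lie within the scatter. The estimate for compound 4 in this assay is 20000 nM, range 6000 nM to 60000 nM.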

Compound 4, concentration for 50% growth inhibition: 7630 nM
The estimate for compound 4 lay 2.6-fold (0.42 log units) above the measured number; the measured number falls inside the stated range.
By their numbers in this assay, from the lowest: compound 4; then compounds 2, 1 and 3 (each within the scatter of the next).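

In this assay, dimethylamino in place of fluoro on an aromatic carbon, para to a large group, gives a 3.5-fold lower number from compound 3 to compound 4 (0.55 log units; beyond the scatter) and is a modest step. It is the only one-change step in the series that lies beyond the scatter, whereas a 1.1-fold lower number from compound 1 to compound 2 (0.03 log units; within the scatter), at a different place and with a different group, does not, so this position is the first shown to respond to a change of group. No measurement shown accounts for the step.

From the compounds shown here alone, whether a primary amine or a carboxylic acid at this position would give a lower or a higher number remains open. Also open, going by these compounds, is whether a longer chain on the nitrogen would keep the step.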